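Ring oxygen substituent: from 3-hydroxypropyl to 4-fluorobenzyl

The compounds below may be only part of what the source reports. "The series", "measured", "known", "first", "only" and "open" are said of these compounds alone.

In a functional assay on a cell-free system (plasma, Oryctolagus cuniculus) for inhibition, with stated times of 5 min, 1 min and 6 min (a lower number here means a stronger inhibitor, a higher number a weaker inhibitor), compound 1 (`CCOC(=O)c1c(C)nc(-c2cccc(C#N)c2)n1O`) gives 17600 nM and compound 2 (`CCOC(=O)c1c(C)nc(-c2ccc(C#N)cc2)n1OC`) gives 13400 nM while compound 3 (`CCOC(=O)c1c(C)nc(-c2cccc(C#N)c2)n1OCCCO`) gives 11400 nM with all three values within the scatter of one another, so compound 3 is not separated from either of the others.

The next structure is compound 4 (`CCOC(=O)c1c(C)nc(-c2cccc(C#N)c2)n1OCc1ccc(F)cc1`). The change to it is 4-fluorophenyl in place of 2-hydroxyethyl on a saturated chain carbon bound to an oxygen on an aromatic ring and reads in words as 4-fluorophenyl in place of 2-hydroxyethyl on a saturated chain carbon bound to an oxygen on an aromatic ring.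

Within the data shown here, one measured step bears on this place, namely a 1.5-fold lower number from compound 1 to compound 3 (0.19 log units; within the scatter) and it stays within the scatter. Among the measured compounds shown here, no measured compound carries a ring on that oxygen, so the entering 4-fluorophenyl has no direct precedent and the range has to stay wide. On this single small step, no change beyond the scatter is expected, with only a slight lean towards a lower number and no firm direction. The estimated step is a 1.3-fold lower number from compound 3 to compound 4 (0.10 log units; within the scatter) and it should be read as a working guess. Compound 4 is expected at 9000 nM with an estimated range from 3000 nM to 22000 nM for now.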

Compound 4, half-maximal inhibitory concentration: 5880 nM
The estimate for compound 4 lay 1.5-fold (0.18 log units) above the measured number, and the stated range covers the measured number.
By their numbers in this assay, from the lowest: compounds 4, 3, 2 and 1 (each within the scatter of the next, the first and the last beyond it).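

In this assay, replacing 3-hydroxypropyl with 4-fluorobenzyl on the ring oxygen gives a 1.9-fold lower number from compound 3 to compound 4 (0.29 log units; within the scatter), so this change alone does not separate the two compounds, even though a six-membered aromatic ring enters and the hydrogen-bond donor of the chain leaves. Among these compounds, measured from the hydrogen on that oxygen, the picture differs: a 3.0-fold lower number from compound 1 to compound 4 (0.48 log units; beyond the scatter) is the first step at this position to lie beyond the scatter, though it is modest, whereas a 1.5-fold lower number from compound 1 to compound 3 (0.19 log units; within the scatter) did not show that the substituent on this oxygen can shift the number at all. No supporting evidence accompanies this result, so the step stands as an observation only.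

On these data alone, whether the shift belongs to the aromatic ring or to the fluorine remains open, and an unsubstituted benzyl or a 4-chlorobenzyl on the same oxygen would help to separate the two. Also open, as far as these compounds go, is how this position responds to a longer chain ending in phenyl, or to a chain ending in an amine or a carboxylic acid.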